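The source may hold more compounds than are shown below. What is called first, only, known or untested is meant among the compounds shown, and "the series" means these compounds.

Values in a functional assay on MCF7 cells (Homo sapiens) for inhibition, with a stated time of 96 h; on this read-out lower numbers stand for stronger inhibition and higher numbers for weaker inhibition:
- compound 1 `COc1cc(C(=O)c2cn(-c3cccc(C)c3)cc2-c2ccco2)cc(OC)c1OC`: 23 nM
- compound 2 `COc1cc(C(=O)c2cn(-c3cccc(C)c3)cc2-c2nccs2)cc(OC)c1OC`: 20 nM
- compound 3 `COc1cc(C(=O)c2cn(-c3ccc(C)cc3)cc2-c2ccco2)cc(OC)c1OC`: 22 nM

Compound 3, at 22 nM, lies within the usual scatter of both other compounds, so the three cannot be put in any order. They simply form one tight group.

The next compound is compound 4 `COc1cc(C(=O)c2cn(-c3ccc(C)cc3)cc2-c2ncco2)cc(OC)c1OC`, which has 1,3-oxazol-2-yl in place of furan-2-yl on an aromatic carbon.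

Within the data shown here, no oxazole-bearing compound has been measured yet, so the closest guide is a related ring swap at the same place. That swap, 1,3-thiazol-2-yl in place of furan-2-yl, gave a 1.2-fold lower number from compound 1 to compound 2 (0.06 log units; within the scatter). It was made with 3-methylphenyl on the ring nitrogen, whereas compound 4 carries 4-methylphenyl. That difference matters little here, since exchanging one for the other gave a 1.0-fold lower number from compound 1 to compound 3 (0.02 log units; within the scatter).

Neither step rises above the scatter, so no real shift is expected from the new ring, though a single related swap is thin evidence. The expected change is a 1.1-fold higher number from compound 3 to compound 4 (0.06 log units; within the scatter). For compound 4 the estimated value is 25 nM, with an expected range from 12 nM to 55 nM.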

Compound 4, half-maximal inhibitory concentration: 42 nM
Estimate against measurement, compound 4: 1.7-fold (0.23 log units) below, and the stated range covers the measured number.
By their numbers in this assay, from the lowest: compounds 2, 3, 1 and 4 (each within the scatter of the next, the first and the last beyond it).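

Putting 1,3-oxazol-2-yl in place of furan-2-yl adds a second hetero atom to the five-membered ring and a second hydrogen-bond acceptor while keeping the same number of heavy atoms, and it gives a 1.9-fold higher number from compound 3 to compound 4 (0.28 log units; within the scatter) in this assay for this change. Among these compounds, this is the first ring exchange at this place, two ring bonds from the ring nitrogen, to be read with a 4-methylphenyl group on that nitrogen, and like the earlier exchange to 1,3-thiazol-2-yl, it does not move the number clear of the scatter. No other measurement bears on this result, so what lies behind the small step cannot be told.

The compounds shown leave open whether this place would accept something other than a five-membered aromatic ring, such as a phenyl or pyridine ring, an amine or a carboxylic acid. They also leave open whether 1,3-oxazol-2-yl would give a similar number with 3-methylphenyl on the ring nitrogen.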